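Thiosemicarbazide series: ring exchange at the thiocarbonyl carbon

The source may hold more compounds than are shown below. What is called first, only, known or untested is meant among the compounds shown, and "the series" means these compounds.

Measured so far:
compound 1 `Cc1cccc(/C(N)=N/NC(=S)N2CCSCC2)n1` — 47.2%
compound 2 `N/C(=N\NC(=S)N1CCSCC1)c1ccccn1` — 34%

In a functional assay on A-375 cells (Homo sapiens) for cytotoxicity, read by MTT assay, with a stated time of 72 h, tested at 1 uM (a higher number here means more inhibition of growth at the concentration tested, a lower number less inhibition of growth), compound 1 gives 47.2%, the higher of the two numbers recorded. Compound 2 gives 34% in this assay; the step of a number 13.2 percentage points lower from compound 1 to compound 2 (beyond the scatter) is the only measured one in the set, and it concerns the aromatic part of the core, not the thiocarbonyl side.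

Compound 3 `Cc1cccc(/C(N)=N/NC(=S)N2CCCCC2)n1` is not yet measured. It differs from compound 1 by piperidin-1-yl in place of thiomorpholin-4-yl on a thiocarbonyl carbon. Among the compounds with values here, no measured step touches this position, so nothing in the data speaks for a change in either direction; the expectation is a step within the scatter. Compound 3 is therefore estimated at 45% in this assay, between 28% and 62%, which means an expected step of a number 2.2 percentage points lower from compound 1 to compound 3 (within the scatter).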

Compound 3, percent growth inhibition at one concentration: 49.9%
For compound 3 the middle estimate is 4.9 percentage points below the measured one; the range from low to high includes it.
By their numbers in this assay, from the lowest: compound 2; then compounds 1 and 3 (each within the scatter of the next).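

In this assay, the thiocarbonyl side of the series now has its first measured step (a number 2.7 percentage points higher from compound 1 to compound 3 (within the scatter)). Piperidin-1-yl and thiomorpholin-4-yl on a thiocarbonyl carbon cannot be told apart here, so the ring sulfur of compound 1 is not required for the growth inhibition seen at this position, whereas the only earlier step (a number 13.2 percentage points lower from compound 1 to compound 2 (beyond the scatter)) lay on the aromatic part of the core and went beyond the scatter. No measurement bearing on the reason for this result is available.

As far as these compounds go, whether a ring oxygen, as in morpholin-4-yl, or a second ring nitrogen, as in piperazin-1-yl, would be tolerated equally at this carbon remains open. Also open, from the compounds shown here alone, is whether the piperidin-1-yl exchange gives the same result on the core of compound 2, which lacks the methyl group.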